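This account rests on a few compounds, and the source may have more. Where it says the series, first, only, none or still open, it means among the compounds named here.

Measured so far in a functional assay on cells (Rhabdomyosarcoma cell, Homo sapiens) for cytotoxicity; on this read-out lower numbers stand for stronger inhibition and higher numbers for weaker inhibition:
Compound 1 `Brc1ccc(C(c2ccccc2)N2CCN(c3ncnc4c3cnn4-c3ccccc3)CC2)cc1` gives > 25000 nM, a limit of the assay.
Compound 2 `Cc1noc(C)c1C(c1ccccc1)N1CCN(c2ncnc3c2cnn3-c2ccccc2)CC1` gives > 25000 nM, a limit of the assay.
Compound 3 `Clc1ccc(C(c2ccccc2)N2CCN(c3ncnc4c3cnn4-c3ccccc3)CC2)cc1` gives > 25000 nM, a limit of the assay.

Compound 3 thus stands only at a limit in this assay, as do the two other values shown (the limit of > 25000 nM in this assay, at which 3 of the 3 values shown sit). Compound 4 `c1ccc(C(c2nccs2)N2CCN(c3ncnc4c3cnn4-c3ccccc3)CC2)cc1` differs from compound 3 by 1,3-thiazol-2-yl in place of 4-chlorophenyl on a saturated chain carbon bound to an amine nitrogen in a ring and an aromatic carbon. The measured steps that touch the same position, a step that the two limits leave unreadable from compound 2 to compound 3 and a step that the two limits leave unreadable from compound 1 to compound 2, are both left unreadable by the limits, and so is a step that the two limits leave unreadable from compound 1 to compound 3. No readable step size is therefore available, and no change at this position has moved any compound off the limit. Compound 4 is expected to sit at the limit again, and the expected step is a step that the limit leaves unreadable from compound 3 to compound 4. Compound 4 is estimated at 35000 nM, with a range from 10000 nM to 120000 nM.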

Compound 4, half-maximal inhibitory concentration: > 25000 nM
Compound 4: a limit, no number; the forecaster's own chance of this, stated with the estimate: 80%; the middle value is on the limit's open side.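

In this assay compound 4 gives > 25000 nM, a limit of the assay, so its steps from compound 1, compound 2 and compound 3 cannot be read. The compounds shown leave open whether any group at this position gives a measurable value.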